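The compounds below may be only part of what the source reports. "The series", "measured", "known", "first", "only" and "open" are said of these compounds alone.

Compound 1 `COc1cc(C(=O)N/N=C/c2ccccc2C(F)(F)F)cc(OC)c1OC`: 45%
Compound 2 `COc1cc(C(=O)N/N=C/c2ccc(F)c(F)c2)cc(OC)c1OC`: 35.1%
Compound 3 `COc1cc(C2=NN(C(C)=O)C(c3ccc(C(F)(F)F)cc3)O2)cc(OC)c1OC`: -11%

In a functional assay on PC-3 cells (Homo sapiens) for antiproliferative activity, read by MTT assay, tested at 1 uM (a higher number here means a stronger effect of the compound at the concentration tested, a lower number a weaker effect), compound 2 gives 35.1%, the second highest of the three numbers. Compound 1 gives 45%, a number within the scatter of compound 2, while compound 3 gives -11%, a number beyond the scatter below compound 2. Among the compounds with values here, no pair of measured compounds differs in a single place, so no measured step guides the next comparison.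

Compound 4 `COc1cc(C(=O)N/N=C/c2cc(Cl)cc(Cl)c2)cc(OC)c1OC` differs from compound 2 by 3,5-dichlorophenyl in place of 3,4-difluorophenyl on a carbon with a double bond to nitrogen. Within the data shown here, nothing among the measured compounds shows how such an exchange acts in this assay. The step of a number 2.9 percentage points higher from compound 2 to compound 4 (within the scatter) is expected to be small, none beyond the scatter, in no fixed direction. Compound 4 is therefore expected to give 38%, with a range from 15% to 60%.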

Compound 4, a percentage reported as inhibition, at one concentration (the size of the read-out at that concentration, not a potency): 22.1%
The estimate for compound 4 lay 15.9 percentage points above the measured number; the measured number falls inside the stated range.
By their numbers in this assay, from the lowest: compound 3; then compound 4; then compounds 2 and 1 (each within the scatter of the next).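

In this assay the exchange of 3,4-difluorophenyl for 3,5-dichlorophenyl gives a number 13 percentage points lower from compound 2 to compound 4 (beyond the scatter) as the first step read at this place, on a carbon with a double bond to nitrogen. The read-out therefore responds to which halogenated phenyl group sits there, even though the two groups match in heavy-atom count. Nothing measured here accounts for the step.

The exchange alters both the halogen and its placement, so the two remain unseparated. On these data alone, how an amine or a carboxylic acid on the phenyl group would fare remains open.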